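The compounds below may be only part of what the source reports. "The series", "measured", "known", "first", "only" and "open" are said of these compounds alone.

In a functional assay on MDA-MB-231 cells (Homo sapiens) for cytotoxicity, read by MTT assay, with a stated time of 48 h (a lower number here means a stronger inhibitor, a higher number a weaker inhibitor), compound 1 `Fc1cccc(-c2nc(Nc3ccccc3)c3cc(F)ccc3n2)c1` gives 47800 nM. Compound 2 `Fc1cccc(-c2nc(Nc3ccccc3F)c3cc(F)ccc3n2)c1` gives only the assay limit > 50000 nM. Compound 3 `Fc1cccc(-c2nc(Nc3cccc(Cl)c3)c3cc(F)ccc3n2)c1` likewise gives only the assay limit > 50000 nM.

Compound 3 thus stands at the limit (the limit of > 50000 nM in this assay, at which 2 of the 3 values shown sit), with no number of its own. Compound 4 `Nc1ccccc1Nc1nc(-c2cccc(F)c2)nc2ccc(F)cc12` differs from it by 2-aminophenyl in place of 3-chlorophenyl on a nitrogen on an aromatic ring. Going by the values given here, no measured step involves a 2-aminophenyl group. The steps that do exist, an at least 1.0-fold higher number from compound 1 to compound 2 (0.01 log units; that floor lies within the scatter) and an at least 1.0-fold higher number from compound 1 to compound 3 (0.01 log units; that floor lies within the scatter), are both floors that lie within the scatter, and a step that the two limits leave unreadable from compound 2 to compound 3 cannot be read. These steps therefore give no ground to expect a move beyond the scatter for compound 4. Compound 4 is estimated at 50000 nM, between 15000 nM and 150000 nM, which means an expected step of a number no higher from compound 3 to compound 4 (the limit leaves the size open) that stays within the scatter, with the result likely again a limit.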

Compound 4, half-maximal inhibitory concentration: > 50000 nM
Compound 4: only a limit was reported; the forecaster's own chance of this, stated with the estimate: 60%; the middle value sits exactly at the limit.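

In this assay, 2-aminophenyl on this nitrogen gives the same outcome as 3-chlorophenyl, a limit and no number of its own: the limit of > 50000 nM in this assay, at which 3 of the 4 values shown sit. So even a group that carries a hydrogen-bond donor and acceptor, where 3-chlorophenyl has none, produces no readable value at this position. Going by these compounds alone, the only readable step is an at least 1.0-fold higher number from compound 1 to compound 4 (0.01 log units; that floor lies within the scatter), and the steps to compound 4 from compound 2 and from compound 3 cannot be read.

From the compounds shown here alone, it remains open whether a carboxylic acid or a longer amine chain at this place would bring a readable value. Going by these compounds, how far compound 2, compound 3 and compound 4 lie beyond the limit also stays unknown.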